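The compounds below may be only part of what the source reports. "The series", "measured", "known", "first", "only" and "open" are said of these compounds alone.

- Compound 1 `CN1CCC(C(=O)N2Cc3c(NC(=O)NCc4ccccc4)n[nH]c3C2(C)C)CC1`: > 225000 nM
- Compound 2 `CC1(C)c2[nH]nc(NC(=O)c3ccc(F)cc3)c2CN1C(=O)C1CCN(C2CC2)CC1`: > 225000 nM
- Compound 3 `CN1CCC(C(=O)N2Cc3c(NC(=O)c4cccs4)n[nH]c3C2(C)C)CC1`: not yet measured

In a physicochemical assay for solubility, at pH 7 (a lower number here means a less soluble compound, a higher number a more soluble compound), compound 1 gives > 225000 nM, which is a limit of the assay and not a number. Compound 2 gives > 225000 nM, which is likewise a limit. Compound 1 and compound 2 thus share (the limit of > 225000 nM in this assay, at which 2 of the 2 values shown sit). Compound 3 carries thiophen-2-yl in place of benzylamino on a carbonyl carbon. Among the compounds with values here, no measured step shows what such a change does. With compound 1 and compound 2 both at the limit of > 225000 nM in this assay, at which 2 of the 2 values shown sit, an at least 1.3-fold lower number from compound 1 to compound 3 (0.12 log units; that floor lies within the scatter) is expected to be small and, if visible at all, downward. For compound 3 the estimate is 170000 nM, with an expected range from 60000 nM to 225000 nM.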

Compound 3, solubility: 155000 nM
Beside the measured number, compound 3's estimate is 1.1-fold (0.04 log units) above it; the range from low to high includes it.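

In this assay, compound 3, with thiophen-2-yl on this carbonyl carbon, gives a number and not a limit. The change from benzylamino to thiophen-2-yl brings an at least 1.4-fold lower number from compound 1 to compound 3 (0.16 log units; that floor lies within the scatter). That step has only a floor, because compound 1 stands at a limit of the assay: the limit of > 225000 nM in this assay, at which 2 of the 3 values shown sit.

The compounds shown leave open how large the step really is. They also leave open what phenyl, a longer alkyl chain or a carboxylic acid on this carbonyl carbon would give in this assay.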